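The source may report more compounds than this note shows. Statements on the series, on what has been measured and on what is new or still open speak of the compounds shown alone.

Three compounds sharing one core have been measured in a physicochemical assay for solubility, with a stated time of 20 h, at pH 6.8; on this read-out lower numbers stand for lower solubility and higher numbers for higher solubility:

compound 1, `O=S1(=O)Cc2nc(-c3cc(F)c(Cl)cc3F)nc(N3CCC(CO)CC3)c2C1`, gives 16000 nM
compound 2, `NC(=O)CC1CCN(c2nc(-c3cc(F)c(Cl)cc3F)nc3c2CS(=O)(=O)C3)CC1`, gives 15000 nM
compound 3, `O=S1(=O)Cc2nc(-c3cc(F)c(Cl)cc3F)nc(N3CCC(O)CC3)c2C1`, gives 91000 nM

Compound 3 holds the highest number of the three, and both of its gaps to the other two lie beyond the usual scatter of this kind of measurement. The unmeasured compound 4, `O=S1(=O)Cc2nc(-c3cc(F)c(Cl)cc3F)nc(N3CCC(CCO)CC3)c2C1`, differs from compound 3 in one place: 2-hydroxyethyl in place of hydroxy on a saturated ring carbon. Among the compounds with values here, two measured steps bear on this change, since each of them also swaps the group on that same saturated ring carbon. Replacing a hydroxymethyl with a hydroxy gave a 5.7-fold higher number from compound 1 to compound 3 (0.75 log units; beyond the scatter), and replacing a carbamoylmethyl with a hydroxy gave a 6.1-fold higher number from compound 2 to compound 3 (0.78 log units; beyond the scatter). Compound 4 moves in the opposite direction, trading the hydroxy for a 2-hydroxyethyl chain, so a drop of roughly the size seen in those two steps is expected in this assay, perhaps a little more because compound 1 already sits at 16000 nM with the shorter hydroxymethyl. For compound 4 a step of about a 9.1-fold lower number from compound 3 to compound 4 (0.96 log units; beyond the scatter) is therefore expected. Compound 4 is estimated at 10000 nM, with a likely range from 4000 nM to 30000 nM.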

Compound 4, solubility: 23000 nM
Compound 4: middle estimate off by 2.3-fold (0.36 log units), on the low side; the range from low to high includes it.
By their numbers in this assay, from the lowest: compounds 2, 1 and 4 (each within the scatter of the next); then compound 3.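

In this assay, moving from 4-hydroxypiperidin-1-yl to 4-(2-hydroxyethyl)piperidin-1-yl gives a 4.0-fold lower number from compound 3 to compound 4 (0.60 log units; beyond the scatter), so a third group that places a chain between the ring carbon and its end group now stands apart from compound 3, which has the hydroxy directly on the ring carbon. Lengthening the chain gives a 1.4-fold higher number from compound 1 to compound 4 (0.16 log units; within the scatter), and hydroxymethyl in place of the carbamoyl end gives a 1.5-fold higher number from compound 2 to compound 4 (0.19 log units; within the scatter), so among compound 1, compound 2 and compound 4 neither chain length nor end group makes a readable difference, and only compound 3 separates from the rest. No measurement shown here offers an explanation for this separation.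

The compounds shown leave open whether the higher number is tied to the hydroxy itself or would also appear with another small group directly on that ring carbon, such as an amine or a carboxylic acid. They also leave open whether a longer chain than 2-hydroxyethyl, or a chain ending in an amine, would stay with compound 1, compound 2 and compound 4.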